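A second chloro on the aromatic ring of compound 1

The source may report more compounds than this note shows. Statements on the series, on what has been measured and on what is new or still open speak of the compounds shown alone.

Among the measured compounds shown here, in a functional assay on MCF7 cells (Homo sapiens) for antiproliferative activity, read by MTT assay, with a stated time of 72 h (a higher number here means a weaker inhibitor, a lower number a stronger inhibitor), compound 1 `CC1=CC[C@H]2[C@H](CC[C@]2(C)O)C(C)(C)[C@@H]1CC[C@H]1[C@]2(C)CC[C@H](OC(=O)c3ccc(Cl)cc3)C(C)(C)O[C@H]2CC[C@@]1(C)O` gives 24100 nM as the only actual number so far. Compound 2 `CC1=CC[C@H]2[C@@H]1CC=C(C)[C@@H](CC[C@H]1[C@]3(C)CC[C@H](OC(=O)c4ccc(C)cc4)C(C)(C)O[C@H]3CC[C@@]1(C)O)C2(C)C` stands at > 50000 nM as a limit of the assay and not a number. Compound 3 `CC1=CC[C@H]2[C@H](CC[C@]2(C)O)C(C)(C)[C@@H]1CC[C@H]1[C@]2(C)CC[C@H](OC(=O)c3ccc(Cl)c(Cl)c3)C(C)(C)O[C@H]2CC[C@@]1(C)O` differs from compound 1 by chloro in place of hydrogen on an aromatic carbon in the change from 4-chlorophenyl to 3,4-dichlorophenyl, with the new chloro ortho to a chloro group. For the measured compounds named here, no measured step guides this change. The estimated 1.2-fold lower number from compound 1 to compound 3 (0.08 log units; within the scatter) stays within the usual scatter of this assay with no clear direction expected. Compound 3 is estimated at 20000 nM with an expected range from 9000 nM to 45000 nM in this measurement.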

Compound 3, half-maximal inhibitory concentration: 11900 nM
Estimate against measurement, compound 3: 1.7-fold (0.23 log units) above; the range from low to high includes it.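

In this assay, among the compounds shown here, chloro in place of hydrogen on the aromatic ring gives a 2.0-fold lower number from compound 1 to compound 3 (0.31 log units; beyond the scatter), a first measured change at this place, ortho to a chloro group and meta to a large group. It shows that the 3,4-dichlorophenyl ester keeps activity on these cells and that the second chloro moves the number modestly towards a stronger inhibitor. Nothing measured here accounts for this step. From the compounds shown here alone, with one step at this place, it remains open whether the shift is particular to chloro. A fluoro, a methoxy or an amine on the same aromatic carbon could move the number either way.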